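This account rests on a few compounds, and the source may have more. Where it says the series, first, only, none or still open, it means among the compounds named here.

Measured so far:

Compound 1, `COC(=O)c1sc2cc(-c3cccs3)cnc2c1N`: in a functional assay on MCF7 cells (Homo sapiens) for inhibition, read by sulforhodamine B assay, with a stated time of 48 h (a higher number here means a weaker inhibitor of growth, a lower number a stronger inhibitor of growth), compound 1 gives 26900 nM.
Compound 2, `COC(=O)c1sc2cc(-c3ccc(-c4cccs4)s3)cnc2c1N`: in this assay compound 2 gives 1000 nM.

Compound 1 stands at the highest of the two numbers; its nearest neighbour is compound 2, reached by a 27-fold lower number from compound 1 to compound 2 (1.43 log units; beyond the scatter), a large step through thiophen-2-yl in place of hydrogen on an aromatic carbon.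

The step now followed leads from compound 1 to compound 3, `COC(=O)c1sc2cc(-c3cnn(C)c3)cnc2c1N`, by 1-methyl-1H-pyrazol-4-yl in place of thiophen-2-yl on an aromatic carbon. Among the measured compounds shown here, no measured step bears on this exchange: the only step known, from compound 1 to compound 2, lengthens the thiophen-2-yl group rather than replacing it, so it offers no guide to what a 1-methyl-1H-pyrazol-4-yl group does at this place. With nothing to point either way, no step beyond the scatter is expected in this assay. Compound 3 is therefore estimated at 30000 nM, in the range 8000 nM to 110000 nM, which means an expected step of a 1.1-fold higher number from compound 1 to compound 3 (0.05 log units; within the scatter).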

Compound 3, concentration for 50% growth inhibition: > 150000 nM
Compound 3: no number, only a limit; the forecaster's own chance of this, stated with the estimate: 20%; at least 5.0-fold (0.69 log units) between middle value and limit.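

Replacing the ring at this place, and not only extending it, changes the read-out: 1-methyl-1H-pyrazol-4-yl in place of thiophen-2-yl gives an at least 5.5-fold higher number from compound 1 to compound 3 (0.74 log units; beyond the scatter), so this aromatic carbon, two atoms from the ring nitrogen, does not treat these two five-membered aromatic rings alike. The value of compound 3 in this assay is a limit of the assay and not a number: the limit of > 150000 nM in this assay, at which 1 of the 3 values shown sits.
Read with a 27-fold lower number from compound 1 to compound 2 (1.43 log units; beyond the scatter), changes at this one place now move the number in both directions from compound 1.

Going by these compounds, the true size of the step to compound 3 stays open, as does whether it follows the ring nitrogens or the methyl group of 1-methyl-1H-pyrazol-4-yl. Also open, on these data alone, is what a phenyl ring, an amine or a longer chain would do at this place.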